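The source may hold more compounds than are shown below. What is called first, only, known or untested is meant among the compounds shown, and "the series" means these compounds.

In an ADME assay on L02 cells (Homo sapiens) for cytotoxicity, read by MTT assay, with a stated time of 48 h (a higher number here means a weaker inhibitor, a lower number a stronger inhibitor), compound 1 `CCn1c(C(=O)NCCN(C)C)ccc1C(CC)(CC)c1ccc(OCC(=O)C(C)(C)C)c(C)c1` gives 2500 nM and compound 2 `CCn1c(C(=O)NCCN(C)C)ccc1C(CC)(CC)c1ccc(OCC(O)C(C)(C)C)c(C)c1` gives 2600 nM, so the two stand level within the scatter. Compound 3 `CC[C@@H](C)[C@H](NC(=O)c1ccc(C(CC)(CC)c2ccc(OCC(=O)C(C)(C)C)c(C)c2)n1CC)C(=O)O` keeps the (tert-butyl)carbonyl of compound 1 and differs on the amide-type nitrogen: 1-carboxy-2-methylbutyl in place of 2-(dimethylamino)ethyl on an amide-type nitrogen. Among the measured compounds shown here, the only measured step, a 1.0-fold higher number from compound 1 to compound 2 (0.02 log units; within the scatter), lies elsewhere in the molecule, so no measured step bears directly on this exchange. Even so, replacing 2-(dimethylamino)ethyl with 1-carboxy-2-methylbutyl is a large change, and the expected shift in this assay is towards a higher number, an estimated 8.0-fold higher number from compound 1 to compound 3 (0.90 log units; beyond the scatter). Compound 3 is expected near 20000 nM, within an estimated range of 6000 nM to 60000 nM.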

Compound 3, half-maximal inhibitory concentration: 1500 nM
Beside the measured number, compound 3's estimate is 13-fold (1.12 log units) above it, and the stated range ends above it.
By their numbers in this assay, from the lowest: compounds 3, 1 and 2 (each within the scatter of the next).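

In this assay the exchange of 2-(dimethylamino)ethyl for 1-carboxy-2-methylbutyl on the amide-type nitrogen gives a 1.7-fold lower number from compound 1 to compound 3 (0.22 log units; within the scatter) and so leaves the two compounds level. Among the compounds shown here, the earlier pair differed only at the other end of the molecule, so this is the first sign that the amide-type nitrogen can carry a very different chain without moving the number beyond the scatter. Nothing at hand explains this result.
Still open, going by these compounds, is whether a plain ethyl or a chain ending in a primary amine on this nitrogen would also stay level. The compounds shown also leave open how the opposite stereoisomers of 1-carboxy-2-methylbutyl would read.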